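The source may report more compounds than this note shows. Statements on the series, on what has been measured and on what is new or still open speak of the compounds shown alone.

In a functional assay on A549 cells (Homo sapiens) for antiproliferative activity, read by MTT assay, with a stated time of 72 h (a higher number here means a weaker inhibitor, a lower number a stronger inhibitor), three compounds have been measured so far. Compound 1 `COc1ccc(N2C(=O)COc3ccc(-c4ccc(O)cc4)cc32)cc1` reports only a limit, > 40000 nM in this case. Compound 2 `COc1ncc(-c2ccc3c(c2)N(C2CCCCC2)C(=O)CO3)cc1NS(=O)(=O)c1ccc(F)cc1` gives 24600 nM as its half-maximal inhibitory concentration. Compound 3 `CC(C)N1C(=O)COc2ccc(-c3cnc(Cl)c(NS(=O)(=O)c4ccc(F)cc4)c3)cc21` gives 5100 nM and so holds the lower of the two actual numbers, with its gap to compound 2 lying beyond the scatter.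

Compound 4 `O=C1COc2ccc(-c3cnc(Cl)c(NS(=O)(=O)c4ccc(F)cc4)c3)cc2N1c1ccccc1` departs from compound 3 in one place: phenyl in place of isopropyl on an amide-type nitrogen in a ring here means phenyl in place of isopropyl on an amide-type nitrogen in a ring. Among the compounds with values here, no measured pair isolates this change, so any expectation is indirect. Compound 2, which also carries a ring on that nitrogen but differs elsewhere too, stands at 24600 nM and points to a moderate step toward a higher number in this assay for the new compound. The expected move is a 1.8-fold higher number from compound 3 to compound 4 (0.25 log units; within the scatter) in this estimate, with wide uncertainty. For compound 4 the estimated value is 9000 nM within an expected range of 3000 nM to 30000 nM in this assay.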

Compound 4, half-maximal inhibitory concentration: 14700 nM
Beside the measured number, compound 4's estimate is 1.6-fold (0.21 log units) below it; the measured number falls inside the stated range.
By their numbers in this assay, from the lowest: compound 3; then compounds 4 and 2 (each within the scatter of the next). At a limit, above all of these: compound 1.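

In this assay, within the data shown here, the replacement of isopropyl by phenyl on the amide-type nitrogen in a ring gives a 2.9-fold higher number from compound 3 to compound 4 (0.46 log units; beyond the scatter) and is the first change at this position to be isolated in a single pair. The position is therefore not indifferent to the group it carries, although compound 4 still gives a measured number rather than a limit. Nothing shown accounts for the size of this step.

The compounds shown leave open how a methyl, a benzyl or a hydroxyethyl chain on this nitrogen would compare with isopropyl and phenyl. A single pair also cannot say whether the same step would appear with a different group elsewhere on the shared core.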